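This account rests on a few compounds, and the source may have more. Where it says the series, first, only, none or still open, it means among the compounds named here.

In a functional assay on cells (Endothelial cell, Bos taurus) for antiproliferative activity (a lower number here means a stronger inhibitor, a higher number a weaker inhibitor), compound 1 (`COc1ccc(/C(F)=C(/F)c2cc(OC)c(OC)c(OC)c2)cc1N`) gives 3600 nM and stands second highest of three numbers. Compound 2 (`COc1ccc(/C(F)=C\c2cc(OC)c(OC)c(OC)c2)cc1F`) gives 23000 nM and compound 3 (`COc1cc(/C(F)=C\c2cc(O)c3ccoc3c2)cc(OC)c1OC`) gives 170 nM and both lie beyond the scatter from compound 1. Compound 4 (`COc1ccc(/C(F)=C(/F)c2cc(OC)c(OC)c(OC)c2)cc1[N+](=O)[O-]`) is still unmeasured and differs from compound 1 in one place, nitro in place of amino on an aromatic carbon. For the measured compounds named here, no measured pair shows this change alone. A step toward a higher number in this assay is expected, modestly beyond the scatter. Going by the values given here, the only hint is compound 2 at 23000 nM without an amino group, though it differs elsewhere too. The expected move is a 2.8-fold higher number from compound 1 to compound 4 (0.44 log units; beyond the scatter) in this estimate. For compound 4 the estimated value is 10000 nM (expected range 2500 nM to 40000 nM).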

Compound 4, half-maximal inhibitory concentration: 749000 nM
For compound 4 the middle estimate is 75-fold (1.87 log units) below the measured one; measured number above the stated range.
By their numbers in this assay, from the lowest: compound 3; then compound 1; then compound 2; then compound 4.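

In this assay, the exchange of amino for nitro on this aromatic carbon, ortho to a methoxy group, gives a 210-fold higher number from compound 1 to compound 4 (2.32 log units; beyond the scatter). For the compounds shown here, this is the first pair to isolate a single change, and it shows that this one position can move the number by a large step while the rest of the core of compound 1 stays the same. On these data alone, whether an acetamide or a nitrile at this carbon would give a number nearer compound 1 or compound 4 remains open. Nothing available explains the size of this step.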